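The compounds below may be only part of what the source reports. "The series", "measured", "known", "first", "only" and "open" are said of these compounds alone.

Measured in an ADME assay on WRL68 cells (Homo sapiens) for cytotoxicity; a higher number here means a weaker inhibitor, a lower number a stronger inhibitor:
- compound 1 `CC(=O)OCC1=C[C@H](OCc2ccc(-c3ccccc3)cc2)[C@H](O)[C@@H](O)C1=O` gives 71300 nM
- compound 2 `CO[C@H]1C=C(COC(C)=O)C(=O)[C@H](O)[C@H]1O` gives > 200000 nM as a limit of the assay, not a number

Compound 2 has no numeric reading and stands at the limit of > 200000 nM in this assay, at which 1 of the 2 values shown sits. Compound 3 `CCCCCO[C@H]1C=C(COC(C)=O)C(=O)[C@H](O)[C@H]1O` is compound 2 with butyl in place of hydrogen on a saturated chain carbon bound to an oxygen on a saturated carbon in the change from methoxy to pentyloxy, butyl in place of hydrogen on a saturated chain carbon bound to an oxygen on a saturated carbon. With so few data, a modest step of an at least 1.6-fold lower number from compound 2 to compound 3 (0.22 log units; that floor lies within the scatter) toward stronger inhibition is expected, and a reading that stays at the limit remains possible. For compound 3 the estimated value is 120000 nM within an expected range of 50000 nM to 200000 nM.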

Compound 3, half-maximal inhibitory concentration: 169000 nM
The estimate for compound 3 lay 1.4-fold (0.15 log units) below the measured number; low and high end bracket the measured number.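

In this assay, the change from methoxy to pentyloxy gives an at least 1.1-fold lower number from compound 2 to compound 3 (0.07 log units; that floor lies within the scatter) and this floor does not establish a real drop. For the compounds shown here, compound 3 gives 169000 nM as the first numeric reading with a chain at this position on the shared core. Compound 2 remains a limit, not a number, so the true size of the step stays unfixed: the limit of > 200000 nM in this assay, at which 1 of the 3 values shown sits. As far as these compounds go, whether a longer chain or an amine at this position would move the number clearly beyond the scatter remains open.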